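A few compounds are considered here, and "the series" means these few. Any claim that something is new, unique, unknown or untested is made for them only; others in the source may bear on it.

Measured compounds:
compound 1 `O=S(=O)(Nc1ccc(-c2nc3cc(NS(=O)(=O)c4ccc(Cl)s4)ccc3o2)cc1)c1ccc(Cl)s1`, which gives 43000 nM in an ADME assay on FHC cells (Homo sapiens) for cytotoxicity, read by resazurin assay, with a stated time of 48 h; a higher number here means that more compound is tolerated, a lower number that less compound is tolerated;
compound 2 `COc1ccc(S(=O)(=O)Nc2ccc3oc(-c4ccc(NS(=O)(=O)c5cc(F)ccc5OC)cc4)nc3c2)cc1`, which in this assay reaches only > 100000 nM, a limit of the assay.

Among the measured compounds shown here, compound 1 holds the only number recorded in this assay; the other entry is the limit (the limit of > 100000 nM in this assay, at which 1 of the 2 values shown sits), and for compound 2 that limit is all that is known. Compound 3 `O=S(=O)(Nc1ccc(-c2nc3cc(NS(=O)(=O)c4ccc(Cl)s4)ccc3o2)cc1)c1ccc(Cl)c(C(F)(F)F)c1` has not yet been measured. It differs from compound 1 at a single place (4-chloro-3-(trifluoromethyl)phenyl in place of 5-chlorothiophen-2-yl on a sulfonyl sulfur). For the measured compounds named here, no step between two measured compounds is available here, so the size of this change on tolerated concentration cannot be read from the data. The account therefore rests on compound 1 alone: compound 3 is expected to sit near it, with a step of a 1.1-fold lower number from compound 1 to compound 3 (0.03 log units; within the scatter), that is, no shift beyond the usual scatter. On this basis compound 3 is estimated to give 40000 nM in this assay, within a range from 15000 nM to 100000 nM.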

Compound 3, half-maximal cytotoxic concentration: 63000 nM
Compound 3: the middle estimate sits 1.6-fold (0.20 log units) below what was measured, and the stated range covers the measured number.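

In this assay, among the compounds shown here, putting 4-chloro-3-(trifluoromethyl)phenyl in place of 5-chlorothiophen-2-yl on a sulfonyl sulfur gives a 1.5-fold higher number from compound 1 to compound 3 (0.17 log units; within the scatter), the first step that can be read at this position. A five-membered aromatic ring with 1 hetero atom can thus give way to a larger six-membered aromatic ring of carbon only without a shift beyond the usual scatter, at least in this one pair. The compounds shown offer no measured property that would explain this outcome.

For the compounds shown here, whether the same exchange would hold on another compound remains open, as only this pair speaks for it. Also open, on these data alone, is how a carboxylic acid or an amine on the ring at this sulfonyl sulfur would fare in this assay.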